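The compounds below may be only part of what the source reports. "The series", "measured", "known", "first", "only" and "open" are said of these compounds alone.

Among the measured compounds shown here, in a physicochemical assay for solubility, at pH 7 (a higher number here means a more soluble compound, a lower number a less soluble compound), compound 3 `CC(=O)N1CCC(C(=O)N2Cc3c(NC(=O)c4ccc(F)cc4)n[nH]c3C2(C)C)CC1` gives the only actual number, 204000 nM. Compound 1 `CC(=O)N1CCN(C(=O)N2Cc3c(NC(=O)c4ccc(F)cc4)n[nH]c3C2(C)C)CC1` reports only a limit, > 225000 nM. Compound 2 `CN1CCC(C(=O)N2Cc3c(NC(=O)c4ccsc4)n[nH]c3C2(C)C)CC1` also reports only a limit, > 225000 nM. Compound 4 `CCN1CCC(C(=O)N2Cc3c(NC(=O)c4ccc(F)cc4)n[nH]c3C2(C)C)CC1` now carries ethyl in place of acetyl on an amine nitrogen in a ring. For the measured compounds named here, no measured step makes this same change. The nearest one, an at least 1.1-fold lower number from compound 1 to compound 3 (0.04 log units; that floor lies within the scatter), swaps 4-acetylpiperazin-1-yl for 1-acetylpiperidin-4-yl on a carbonyl carbon, so it offers only weak guidance. On that evidence, no change beyond the scatter is expected in this assay, and the expected step is a 1.0-fold lower number from compound 3 to compound 4 (0.01 log units; within the scatter). Compound 4 is estimated at 200000 nM, with an expected range from 110000 nM to 225000 nM.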

Compound 4, solubility: > 225000 nM
Compound 4 ended at the assay's limit (the forecaster's own chance of this, stated with the estimate: 55%); at least 1.1-fold (0.05 log units) between middle value and limit.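

In this assay, ethyl in place of acetyl on the amine nitrogen in the ring gives an at least 1.1-fold higher number from compound 3 to compound 4 (0.04 log units; that floor lies within the scatter), the first step shown at this position, and compound 4 sits at a limit, so only a floor can be read. The step from compound 1 to compound 4 cannot be read, as both values are limits. The true size of the change stays hidden because the read-out ends here: the limit of > 225000 nM in this assay, at which 3 of the 4 values shown sit.

On these data alone, whether a longer chain or a carboxylic acid on this nitrogen would give a measurable number remains open.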